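From 4-bromophenyl to 4-methoxyphenyl: compound 1 to compound 4

This account rests on a few compounds, and the source may have more. Where it says the series, first, only, none or still open, it means among the compounds named here.

In a functional assay on HCT-116 cells (Homo sapiens) for inhibition, read by sulforhodamine B assay, with a stated time of 72 h (a higher number here means a weaker inhibitor, a lower number a stronger inhibitor), compound 1 `COc1ccc2cc(C(C)c3nnc4n3N=C(c3ccc(Br)cc3)CS4)ccc2c1` gives 11700 nM. Compound 2 `CC(c1ccc(-c2ccccc2)c(F)c1)c1nnc2n1N=C(c1ccccc1)CS2` gives 9700 nM, within the scatter of that number. Compound 3 `COc1ccc(C2=Nn3c(nnc3C(C)c3ccc(-c4ccccc4)c(F)c3)SC2)cc1` gives 4400 nM, a lower number than compound 1 by more than the scatter.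

Compound 4 `COc1ccc(C2=Nn3c(nnc3C(C)c3ccc4cc(OC)ccc4c3)SC2)cc1` keeps the core of compound 1 and changes one group, 4-bromophenyl to 4-methoxyphenyl: methoxy in place of bromo on an aromatic carbon. No direct exchange of bromo for methoxy has been measured in this set. The closest evidence is one modest step, a 2.2-fold lower number from compound 2 to compound 3 (0.34 log units; beyond the scatter), which also introduces methoxy on an aromatic carbon but replaces hydrogen and sits on a different scaffold from compound 1. On that single precedent, a similar modest move toward a stronger inhibitor is expected, though no change beyond the scatter remains possible. The expected change is a 2.0-fold lower number from compound 1 to compound 4 (0.29 log units; within the scatter). For compound 4, the estimated value is 6000 nM, with an expected range of 3000 nM to 12000 nM.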

Compound 4, half-maximal inhibitory concentration: 6500 nM
The estimate for compound 4 lay 1.1-fold (0.03 log units) below the measured number; low and high end bracket the measured number.
By their numbers in this assay, from the lowest: compounds 3, 4, 2 and 1 (each within the scatter of the next, the first and the last beyond it).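

In this assay, the change from 4-bromophenyl to 4-methoxyphenyl on the core of compound 1 gives a 1.8-fold lower number from compound 1 to compound 4 (0.26 log units; within the scatter), so bromo and methoxy cannot be told apart at this position. For the compounds shown here, until now methoxy could be read only against hydrogen, on a different scaffold, in a 2.2-fold lower number from compound 2 to compound 3 (0.34 log units; beyond the scatter); this step is the first direct reading against bromo, on an aromatic carbon para to a large group. No accompanying measurement bears on why the two groups read alike.

With only bromo and methoxy shown at this position on this core, it remains open how hydrogen would read here. Also open, on these data alone, is whether an amine, a carboxylic acid or a longer alkoxy chain in the same place would move the number beyond the scatter.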